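Swapping an Anilide for a Methylpiperazine Amide

The source may report more compounds than this note shows. Statements on the series, on what has been measured and on what is new or still open speak of the compounds shown alone.

Of the compounds shown here, three sharing one core have been tested in a functional assay on PC-3 cells (Homo sapiens) for antiproliferative activity, read by MTT assay, with a stated time of 72 h; a lower number here means a stronger inhibitor, a higher number a weaker inhibitor. Compound 1 `CCCSc1nc(Cl)c2c(n1)N(CCNC(=O)OC(C)(C)C)C(C(=O)N1CCN(C)CC1)N2` gives > 64000 nM, which is a limit of the assay rather than a number. Compound 2 `CCCSc1nc(Cl)c2c(n1)N(Cc1ccccc1)C(C(=O)NCCNC(=O)OC(C)(C)C)N2` gives 29700 nM. Compound 3 `CCCSc1nc(Cl)c2c(n1)N(Cc1ccccc1)C(C(=O)Nc1ccccc1)N2` gives > 64000 nM, again a limit of the assay and not a number. Going by the values given here, compound 3 thus stands at the limit of > 64000 nM in this assay, at which 2 of the 3 values shown sit, and the only measured step, an at least 2.1-fold higher number from compound 2 to compound 3 (0.33 log units; beyond the scatter), reaches that limit through phenyl in place of 2-((tert-butoxycarbonyl)amino)ethyl on an amide-type nitrogen.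

Compound 4 `CCCSc1nc(Cl)c2c(n1)N(Cc1ccccc1)C(C(=O)N1CCN(C)CC1)N2` differs from compound 3 by 4-methylpiperazin-1-yl in place of anilino on a carbonyl carbon. Among the compounds with values here, no measured step covers this exact change. Compound 1 carries the same 4-methylpiperazin-1-yl group on its carbonyl carbon and reached only a limit. Within the data shown here, compound 2 shares the benzyl group of compound 4 and is the only compound with a number. With both neighbours at or close to the limit, compound 4 is expected to sit at 60000 nM, within 20000 nM to 200000 nM. The expected step of an at least 1.0-fold lower number from compound 3 to compound 4 (0.02 log units; that floor lies within the scatter) is therefore not beyond the scatter, with a real chance that only a limit is reported again.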

Compound 4, half-maximal inhibitory concentration: 29800 nM
The estimate for compound 4 lay 2.0-fold (0.30 log units) above the measured number; the range from low to high includes it.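

In this assay, 4-methylpiperazin-1-yl in place of anilino on the carbonyl carbon brings a limit down to a real number: an at least 2.1-fold lower number from compound 3 to compound 4 (0.33 log units; beyond the scatter). The anilino group is the outlier here, not the piperazine, since the open-chain (2-((tert-butoxycarbonyl)amino)ethyl)amino group does no differently: a 1.0-fold higher number from compound 2 to compound 4 (0.00 log units; within the scatter). The amide alone does not settle the result, since with 4-methylpiperazin-1-yl kept, phenyl in place of ((tert-butoxycarbonyl)amino)methyl on the saturated chain carbon also counts: an at least 2.1-fold lower number from compound 1 to compound 4 (0.33 log units; beyond the scatter).

From the compounds shown here alone, the true size of the two steps that start from a limit stays open, because compound 1 and compound 3 carry no number: the limit of > 64000 nM in this assay, at which 2 of the 4 values shown sit. Also open is whether a morpholin-4-yl group or a free primary amine on the carbonyl carbon would give a lower number than compound 4.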